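The source may hold more compounds than are shown below. What is called first, only, known or untested is meant among the compounds shown, and "the series" means these compounds.

Measured in a functional assay with Oryctolagus cuniculus as the target; a lower number here means a stronger inhibitor, a higher number a weaker inhibitor:
compound 1 `COc1ccc(-c2nc(N=C(N)N)sc2-c2ccc(OC)cc2)cc1`: 31000 nM
compound 2 `COc1ccc(-c2nc(CN(C)C)sc2-c2ccc(OC)cc2)cc1`: 96 nM
compound 3 `COc1ccc(-c2nc(CN)sc2-c2ccc(OC)cc2)cc1`: > 100 nM

Compound 3 stands at > 100 nM, which is a limit of the assay and not a number. Compound 4 `COc1ccc(-c2nc(CNC(=O)c3cccnc3)sc2-c2ccc(OC)cc2)cc1` differs from compound 3 by having (pyridin-3-yl)carbonyl in place of hydrogen on an amine nitrogen.

Going by the values given here, no measured step adds a group of this kind, so the guidance is indirect. Among the compounds with values here, the one step at this nitrogen is an at least 1.0-fold higher number from compound 2 to compound 3 (0.01 log units; that floor lies within the scatter), and its floor lies within the scatter, so it says little. The step that the limit leaves unreadable from compound 1 to compound 3 cannot be read. The clearest evidence is a 320-fold lower number from compound 1 to compound 2 (2.51 log units; beyond the scatter), a large step that shows how far this assay can move when the group on this aromatic carbon changes. A shift of some size is therefore expected here, probably smaller than that one and toward a weaker inhibitor, though this direction is uncertain. The expected step is a step that the limit leaves unreadable from compound 3 to compound 4. For compound 4 the estimate is 300 nM, with an expected range from 50 nM to 3000 nM.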

Compound 4, half-maximal inhibitory concentration: 25 nM
Estimate against measurement, compound 4: 12-fold (1.08 log units) above, and the stated range ends above it.
By their numbers in this assay, from the lowest: compound 4; then compound 2; then compound 1.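

In this assay compound 3 is held by a limit of the assay, not a number: the limit of > 100 nM in this assay, at which 1 of the 4 values shown sits. Even so, the step on the amine nitrogen can be read, an at least 4.0-fold lower number from compound 3 to compound 4 (0.60 log units; beyond the scatter), so in this series this nitrogen carries (pyridin-3-yl)carbonyl with a gain rather than a loss. The amide also goes beyond the tertiary amine, a 3.8-fold lower number from compound 2 to compound 4 (0.58 log units; beyond the scatter), and the change of the whole group on the aromatic carbon gives a 1200-fold lower number from compound 1 to compound 4 (3.09 log units; beyond the scatter), the widest span among these compounds.

From the compounds shown here alone, it remains open whether the gain needs the pyridine ring nitrogen or the carbonyl alone, a question that a benzoyl group or an acetyl group on the same nitrogen would address. Also open, going by these compounds, is whether the amide link itself matters, as a sulfonamide or a plain benzylamine in its place would show.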